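Compound 3 to compound 4: dimethylamino replaced by methoxymethyl

The source may hold more compounds than are shown below. What is called first, only, known or untested is meant among the compounds shown, and "the series" means these compounds.

In a functional assay (trachea) with Cavia porcellus as the target (on this read-out higher numbers stand for an effect only at larger amounts of compound and lower numbers for an effect already at smaller amounts), compound 1 (`CCCn1c(=O)n(CC)c(=O)c2[nH]cnc21`) gives 1300 nM, compound 2 (`C=CCn1c(=O)c2[nH]cnc2n(CCC)c1=O`) gives 1600 nM and compound 3 (`CCCn1c(=O)n(CCN(C)C)c(=O)c2[nH]cnc21`) gives 2700 nM. Compound 3 is placed by two steps: a 2.1-fold higher number from compound 1 to compound 3 (0.32 log units; beyond the scatter), and a 1.7-fold higher number from compound 2 to compound 3 (0.23 log units; within the scatter). Compound 4 (`CCCn1c(=O)n(CCCOC)c(=O)c2[nH]cnc21`) carries methoxymethyl in place of dimethylamino on a saturated chain carbon, two bonds along the chain from an aromatic nitrogen. Among the measured compounds shown here, no measured step makes this exchange directly. The nearest evidence is the modest pair of steps above, together with a 1.2-fold higher number from compound 1 to compound 2 (0.09 log units; within the scatter), so all chain changes so far remain small. A small move towards a lower number is expected, with none beyond the scatter: a 1.5-fold lower number from compound 3 to compound 4 (0.18 log units; within the scatter). The expected value for compound 4 is 1800 nM, with an estimated range of 800 nM to 4000 nM.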

Compound 4, half-maximal effective concentration: 2900 nM
Estimate against measurement, compound 4: 1.6-fold (0.21 log units) below; low and high end bracket the measured number.
By their numbers in this assay, from the lowest: compounds 1, 2, 3 and 4 (each within the scatter of the next, the first and the last beyond it).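

Methoxymethyl in place of dimethylamino on a saturated chain carbon, two bonds along the chain from an aromatic nitrogen, leaves no readable difference in this assay: a 1.1-fold higher number from compound 3 to compound 4 (0.03 log units; within the scatter). Against the vinyl-bearing chain the picture is the same, with a 1.8-fold higher number from compound 2 to compound 4 (0.26 log units; within the scatter), whereas a 2.2-fold higher number from compound 1 to compound 4 (0.35 log units; beyond the scatter) is a modest step, so only the exchange of hydrogen at this carbon registers. No measurement on these compounds speaks to the reason for this. On these data alone, a carboxylic acid or a longer chain at this place remains open, as does the effect of a ring here. So does whether any group at this carbon gives a step larger than modest.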